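The compounds below may be only part of what the source reports. "The series", "measured", "known", "first", "only" and "open" are said of these compounds alone.

Measured compounds in this series:
- compound 1, `COc1ccc(-c2ccc3c(NCCCNCc4cccc(OC)c4O)ccnc3c2)cc1`: 32000 nM
- compound 2, `COc1cccc(CNCCCNc2ccnc3cc(C4CCCCC4)ccc23)c1O`: 4200 nM
- compound 3, `COc1ccc(F)cc1CNCCCNc1ccnc2cc(C3CCCCC3)ccc12`: 4200 nM

All three values come from a physicochemical assay for solubility, with a stated time of 18 h, at pH 7.4; on this read-out higher numbers stand for higher solubility and lower numbers for lower solubility. Compound 3 stands level with compound 2 at the digits reported, the pair of them giving the lowest numbers of the three; the nearest neighbour is compound 2, with no change at the digits printed from compound 2 to compound 3 (within the scatter), and the furthest is compound 1, which sits well above both.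

Compound 4, `COc1ccc(F)cc1CNCCCNc1ccnc2cc(Oc3ccc(Cl)cc3)ccc12`, has not yet been measured in this assay. It differs from compound 3 at a single position: 4-chlorophenoxy in place of cyclohexyl on an aromatic carbon.

Of the measured steps only a 7.6-fold lower number from compound 1 to compound 2 (0.88 log units; beyond the scatter) bears on this change, since it exchanges a substituent at the same position on the shared core. That step replaced an aromatic group with cyclohexyl and cut the number markedly. Compound 4 reverses part of that move, putting an aromatic ring back through an oxygen link with a chlorine on it. The 4-methoxyphenyl group of compound 1 is not the same as 4-chlorophenoxy, so a full return to the level of compound 1 is not assumed. A modest rise is therefore expected, on the order of a 1.4-fold higher number from compound 3 to compound 4 (0.15 log units; within the scatter). Compound 4 is estimated at 6000 nM, within 2500 nM to 15000 nM.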

Compound 4, solubility: 14500 nM
Compound 4: middle estimate off by 2.4-fold (0.38 log units), on the low side; low and high end bracket the measured number.
By their numbers in this assay, from the lowest: compounds 2 and 3 (each within the scatter of the next); then compound 4; then compound 1.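

In this assay, replacing cyclohexyl with 4-chlorophenoxy on the aromatic carbon gives a 3.5-fold higher number from compound 3 to compound 4 (0.54 log units; beyond the scatter) and so shows that this position still moves the read-out when the saturated chain carries 5-fluoro-2-methoxyphenyl. For the compounds shown here, the only earlier step at this position, a 7.6-fold lower number from compound 1 to compound 2 (0.88 log units; beyond the scatter) with 2-hydroxy-3-methoxyphenyl on the chain, ran from an aryl group to cyclohexyl, and the new step runs from cyclohexyl to an aryloxy group, so in both pairs the number is lower on the cyclohexyl side and neither step goes against this, though two pairs with different entering groups make only a narrow pattern. No measurement shown gives a reason for the rise.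

Going by these compounds alone, the single exchange changes the ring type, the oxygen link and the chlorine together, so phenoxy without the chlorine and 4-chlorophenyl without the oxygen would be needed to separate their contributions. Also open, on these data alone, is how a non-aromatic group containing an amine, such as morpholine or piperazine, would read at this position against cyclohexyl and 4-chlorophenoxy.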